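Branching the Sulfur Chain in a Selenium-Containing Series

This account rests on a few compounds, and the source may have more. Where it says the series, first, only, none or still open, it means among the compounds named here.

The series shares one core, seen in compound 1 `O=c1c2ccccc2[se]n1-c1nc(SCc2ccccc2)n[nH]1`, compound 2 `CCCCSc1n[nH]c(-n2[se]c3ccccc3c2=O)n1` and compound 3 `CCSc1n[nH]c(-n2[se]c3ccccc3c2=O)n1`. In a functional assay on A549 cells (Homo sapiens) for antiproliferative activity, read by CCK-8 assay, with a stated time of 48 h (on this read-out lower numbers stand for stronger inhibition and higher numbers for weaker inhibition), compound 1 reaches only the limit of > 50000 nM, a limit of the assay rather than a number. In this assay compound 2 gives 12500 nM, and compound 3 gives 39600 nM. Of the two numbers shown, compound 3 stands highest, with compound 2 nearest to it. The measured steps are an at least 4.0-fold lower number from compound 1 to compound 2 (0.60 log units; beyond the scatter) and a 3.2-fold higher number from compound 2 to compound 3 (0.50 log units; beyond the scatter); for the remaining pair, an at least 1.2-fold lower number from compound 1 to compound 3 (0.10 log units; that floor lies within the scatter). The unmeasured compound 4 `CC(C)CSc1n[nH]c(-n2[se]c3ccccc3c2=O)n1` differs from compound 3 by isopropyl in place of methyl on a saturated chain carbon bound to a sulfur. The step of a 3.2-fold higher number from compound 2 to compound 3 (0.50 log units; beyond the scatter) showed a longer chain on the sulfur going with a lower number, and compound 4 carries an isobutylsulfanyl group of the same heavy-atom count as the chain of compound 2. Compound 4 is therefore expected to show a 2.6-fold lower number from compound 3 to compound 4 (0.42 log units; beyond the scatter) in this assay. Compound 4 is estimated at 15000 nM, with a range from 5000 nM to 45000 nM.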

Compound 4, half-maximal inhibitory concentration: 37800 nM
Compound 4: middle estimate off by 2.5-fold (0.40 log units), on the low side; the range from low to high includes it.
By their numbers in this assay, from the lowest: compound 2; then compounds 4 and 3 (each within the scatter of the next). At a limit, above all of these: compound 1.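

In this assay, going from the straight chain of compound 2 to the isobutylsulfanyl group gives a 3.0-fold higher number from compound 2 to compound 4 (0.48 log units; beyond the scatter), so the earlier link between a longer chain and a lower number does not hold for this branched chain of the same heavy-atom count. Placing isopropyl in place of methyl on the saturated chain carbon bound to a sulfur gives a 1.0-fold lower number from compound 3 to compound 4 (0.02 log units; within the scatter), so the ethylsulfanyl and isobutylsulfanyl groups cannot be told apart on this read-out. Compound 1 stands at a limit rather than a number, so an at least 1.3-fold lower number from compound 1 to compound 4 (0.12 log units; that floor lies within the scatter) gives only a floor and no size for the step: the limit of > 50000 nM in this assay, at which 1 of the 4 values shown sits.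

Going by these compounds, whether a longer straight chain such as hexyl, or a chain ending in an amine or a carboxylic acid, would lower the number remains open. On these data alone, it is also open whether a tert-butylsulfanyl group would read like compound 4.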